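This account rests on a few compounds, and the source may have more. Where it says the series, first, only, none or still open, it means among the compounds named here.

Working notes on the series. Compound 1 `NC(=O)/C=C/c1ccncc1-c1ccc2ccccc2c1` gives 12100 nM in a functional assay on HCT-116 cells (Homo sapiens) for inhibition, read by MTT assay, with a stated time of 72 h; on this read-out higher numbers stand for weaker inhibition of growth and lower numbers for stronger inhibition of growth. Compound 2 `COC1CN(C(=O)/C=C/c2ccncc2-c2ccc3ccccc3c2)C1` reports only a limit in this assay, > 30000 nM. Among the measured compounds shown here, the one measured step, an at least 2.4-fold higher number from compound 1 to compound 2 (0.39 log units; beyond the scatter), rests on (the limit of > 30000 nM in this assay, at which 1 of the 3 values shown sits). Compound 3 `O=C(O)[C@@H]1CCCN1C(=O)/C=C/c1ccncc1-c1ccc2ccccc2c1` has no result in this assay, "not determined" (no result reported), so there is no number from which to start. Compound 4 `O=C(/C=C/c1ccncc1-c1ccc2ccccc2c1)N1CCOCC1` differs from compound 3 by morpholin-4-yl in place of 2-carboxypyrrolidin-1-yl on a carbonyl carbon. For the measured compounds named here, no measured step changes this position in the same way, so nothing computed bears directly on it; the only guide is that enlarging the amide substituent from compound 1 to compound 2 moved the number to the limit. On that basis compound 4 is expected to sit in the weak range, estimated at 25000 nM (range 8000 nM to 60000 nM).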

Compound 4, concentration for 50% growth inhibition: 6040 nM
Compound 4: the middle estimate sits 4.1-fold (0.62 log units) above what was measured; the whole stated range lies above it.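

In this assay a ring on the carbonyl carbon need not push the number to the limit: morpholin-4-yl in place of 3-methoxyazetidin-1-yl gives an at least 4.9-fold lower number from compound 2 to compound 4 (0.69 log units; beyond the scatter) and compound 4 thus goes against the reading drawn from the first step. Morpholin-4-yl in place of amino gives a 2.0-fold lower number from compound 1 to compound 4 (0.30 log units; within the scatter) and so brings no real change at this position. The value of compound 2 is a limit, so the size of the step from it is only a bound: the limit of > 30000 nM in this assay, at which 1 of the 4 values shown sits.

Open, as far as these compounds go, is how a piperazin-1-yl group or a longer alkyl chain on the carbonyl carbon would read in this assay here.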